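Carbamoylmethyl in Place of tert-Butyl: What to Expect

The source may report more compounds than this note shows. Statements on the series, on what has been measured and on what is new or still open speak of the compounds shown alone.

Of the compounds shown here, three sharing one core have been measured so far. In an ADME assay on BaF3 cells (Mus musculus) for cytotoxicity (on this read-out lower numbers stand for an effect already at smaller amounts and higher numbers for an effect only at larger amounts of compound), compound 2 `CCCn1ncc2c(Nc3ccc(OC(F)(F)F)cc3)ncnc21` gives 6600 nM, and compound 3 `CC(C)(C)n1ncc2c(Nc3ccc(OC(F)(F)F)cc3)ncnc21` gives 7300 nM. Compound 1 `Cc1nc(C)c(Cn2ncc3c(Nc4ccc(OC(F)(F)F)cc4)ncnc32)s1` reaches only the limit of this assay, > 10000 nM. Among the two actual numbers compound 3 holds the higher one, though its nearest neighbour, compound 2, sits so close that the two cannot be told apart: the step of a 1.1-fold higher number from compound 2 to compound 3 (0.04 log units; within the scatter) lies within the scatter. From compound 1 the steps are floors only, an at least 1.5-fold lower number from compound 1 to compound 2 (0.18 log units; that floor lies within the scatter) and an at least 1.3-fold lower number from compound 1 to compound 3 (0.13 log units; that floor lies within the scatter), and both floors also lie within the scatter.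

Compound 4 `NC(=O)Cn1ncc2c(Nc3ccc(OC(F)(F)F)cc3)ncnc21` has not yet been measured. It differs from compound 3 by carbamoylmethyl in place of tert-butyl on an aromatic nitrogen. Within the data shown here, none of the measured steps concerns an amide-bearing substituent, and the two steps that exchange one saturated substituent for another on that nitrogen stayed within the scatter. On that basis compound 4 is expected to show in this assay a number close to that of compound 3, with the step of a 1.1-fold higher number from compound 3 to compound 4 (0.04 log units; within the scatter) expected to stay within the scatter. Compound 4 is therefore estimated at 8000 nM, with a range from 3500 nM to 18000 nM.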

Compound 4, half-maximal effective concentration: 3300 nM
Compound 4: middle estimate off by 2.4-fold (0.38 log units), on the high side; measured number below the stated range.
By their numbers in this assay, from the lowest: compounds 4, 2 and 3 (each within the scatter of the next, the first and the last beyond it). At a limit, above all of these: compound 1.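

Among these compounds, with carbamoylmethyl on the aromatic nitrogen, this assay shows for the first time a step between two actual numbers at this position that lies beyond the scatter: a 2.2-fold lower number from compound 3 to compound 4 (0.34 log units; beyond the scatter). This exchange keeps the heavy atom count and brings in a hydrogen-bond donor and a hydrogen-bond acceptor, so the position is not indifferent to what sits there, yet the step is modest, and against the propyl of compound 2 it does not separate the two, a 2.0-fold lower number from compound 2 to compound 4 (0.30 log units; within the scatter) being printed as within the scatter. Compound 4 is also the first compound whose step from compound 1 clears the scatter, an at least 3.0-fold lower number from compound 1 to compound 4 (0.48 log units; beyond the scatter), but that step is only a floor, set by a limit and not by a number: the limit of > 10000 nM in this assay, at which 1 of the 4 values shown sits.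

With a single amide-bearing compound, the data cannot tell whether the carbonyl, the amide hydrogen or the whole group goes with the step. As far as these compounds go, how a carboxylic acid, an amine, a methyl amide or a longer chain ending in the same amide would read on that nitrogen remains open.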